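From hydroxy to dimethylamino: estimating compound 3

This account rests on a few compounds, and the source may have more. Where it says the series, first, only, none or still open, it means among the compounds named here.

Measured so far in a functional assay on MCF7 cells (Homo sapiens) for antiproliferative activity, read by MTT assay, with a stated time of 48 h; a lower number here means a stronger inhibitor, a higher number a weaker inhibitor:
- compound 1 `C=C(c1ccc(OC)cc1NC(=O)CO)c1ccc(OC)c2c1C=CC(C)(C)O2` gives 590 nM
- compound 2 `C=C(c1ccc2c(c1)C=CC(C)(C)O2)c1ccc(OC)cc1NC(=O)CN` gives 420 nM

Among the compounds with values here, these two values lie within the usual scatter of repeated measurements, so compound 1 stands level with the only other number available, and the two cannot be ranked.

The compound still to be measured is compound 3 `C=C(c1ccc(OC)cc1NC(=O)CN(C)C)c1ccc(OC)c2c1C=CC(C)(C)O2`, which keeps the core of compound 1 and differs in one place. Dimethylamino stands in place of hydroxy on a saturated chain carbon bound to a carbonyl carbon (dimethylamino in place of hydroxy on a saturated chain carbon bound to a carbonyl carbon). Within the data shown here, no measured pair shows what this exchange does in this assay, so there is no direct guide. The only anchor is the shared level of the two measured compounds, with compound 1 at 590 nM and compound 2 at 420 nM as its two readings. A change beyond the scatter is therefore not expected, and the estimated step is small (a 1.3-fold lower number from compound 1 to compound 3 (0.12 log units; within the scatter)). Compound 3 is expected at 450 nM with 150 nM to 1300 nM as the estimated range.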

Compound 3, half-maximal inhibitory concentration: 2580 nM
Estimate against measurement, compound 3: 5.7-fold (0.76 log units) below; the whole stated range lies below it.
By their numbers in this assay, from the lowest: compounds 2 and 1 (each within the scatter of the next); then compound 3.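

In this assay, within the data shown here, the saturated chain carbon bound to a carbonyl carbon proves sensitive to what it carries: dimethylamino in place of hydroxy gives a 4.4-fold higher number from compound 1 to compound 3 (0.64 log units; beyond the scatter), a modest step but one beyond the scatter, and the only measured step in this set. The earlier compounds shown here could not show this, as no two of them differed in one place. The exchange also alters more than one thing at a time, with a hydroxy group of 1 heavy atom and 1 hydrogen-bond donor giving way to a dimethylamino group of 3 heavy atoms and 0 hydrogen-bond donors, and no measurement is available to explain the higher number.

Going by these compounds, a single pair cannot separate those differences, so it remains open how a methylamino or a methoxy group at this place on the core of compound 1 would compare with hydroxy and dimethylamino. Also open, on these data alone, is whether the same exchange would produce a step of similar size on the core of compound 2, so this result holds only for the core of compound 1.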